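The compounds below may be only part of what the source reports. "The series", "measured", "known", "first", "only" and "open" are said of these compounds alone.

Working notes on the series. The shared core is held constant in compound 3 `CCCN1CCc2c(sc(NC(=O)Nc3ccc(Cl)cc3)c2C(N)=O)C1` and compound 1 `CC(C)CN1CCc2c(sc(NC(=O)Nc3ccc(Cl)cc3)c2C(N)=O)C1`; the two differ only by the change (methyl in place of hydrogen on a saturated chain carbon bound to two saturated chain carbons). In a functional assay (strain AB) with Danio rerio as the target, read by microscopy, with a stated time of 1 h (on this read-out higher numbers stand for an effect only at larger amounts of compound and lower numbers for an effect already at smaller amounts), compound 3 gives 3500 nM, and in this assay compound 1 gives 4510 nM. The change gave a 1.3-fold higher number from compound 3 to compound 1 (0.11 log units; within the scatter).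

Compound 2 `CC[N+]1(C)CCc2c(sc(NC(=O)Nc3ccc(Cl)cc3)c2C(N)=O)C1` has a different core; the difference between the cores of compound 2 and compound 3 is not broken down here. In this assay compound 2 gives 1960 nM, the lowest of the three numbers, within the scatter of compound 3 and beyond the scatter of compound 1.

Compound 4 `CC[N+]1(CC)CCc2c(sc(NC(=O)Nc3ccc(Cl)cc3)c2C(N)=O)C1` is not yet measured in this assay. It arises from compound 2 by the change (methyl in place of hydrogen on a saturated chain carbon bound to an amine nitrogen in a ring). This is the same kind of change as that from compound 3 to compound 1, but not the same: there the place was a saturated chain carbon bound to two saturated chain carbons, here it is a saturated chain carbon bound to an amine nitrogen in a ring. Among the compounds shown this kind of change occurs twice.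

The expectation for the step from compound 2 to compound 4 in this assay is a 1.1-fold higher number from compound 2 to compound 4 (0.05 log units; within the scatter), a small step, because the earlier one gave a 1.3-fold higher number from compound 3 to compound 1 (0.11 log units; within the scatter). The difference in the place around the change adds uncertainty, so a wide range is estimated. For compound 4 in this assay the estimate is 2200 nM, expected to fall between 800 nM and 6000 nM.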

Compound 4, half-maximal effective concentration: 450 nM
Beside the measured number, compound 4's estimate is 4.9-fold (0.69 log units) above it; measured number outside the range, below it.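

In this assay, methyl in place of hydrogen did not carry over from one core to the other as a constant step, since a 4.4-fold lower number from compound 2 to compound 4 (0.64 log units; beyond the scatter), and the comparison with the earlier step shows a real difference: the same change on two cores in this assay, a 1.3-fold higher number (0.11 log units; within the scatter) from compound 3 to compound 1 and a 4.4-fold lower number (0.64 log units; beyond the scatter) from compound 2 to compound 4, 5.6-fold (0.75 log units) apart, beyond the scatter of two such steps

The result therefore shows that the step seen on the core of compound 3 does not predict the step on the core of compound 2, even though the same methyl enters in both cases. It does not show what produces the difference, as the two steps differ both in core and in place: a saturated chain carbon bound to two saturated chain carbons in one, a saturated chain carbon bound to an amine nitrogen in a ring in the other. For the compounds shown here, with only one step on each core, no rule for the series can be drawn, and the lower number for compound 4 stands as a single observation of methyl to ethyl.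

From the compounds shown here alone, it remains open whether a longer chain, such as propyl or butyl, in place of an ethyl of compound 4 would extend or reverse this step. Going by these compounds, it also remains open what the same change would give on the core of compound 3 at a saturated chain carbon bound to an amine nitrogen in a ring.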